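The source may report more compounds than this note shows. Statements on the series, on what has been measured and on what is new or still open speak of the compounds shown alone.

Of the compounds shown here, three have so far been measured in a functional assay on EL4 cells (Mus musculus) for inhibition, tested at 100 uM; a lower number here means less inhibition, a higher number more inhibition at the concentration tested (going by the name of the read-out).

Compound 1 `CSc1nccc2c1ncn2C1O[C@H](CO)[C@@H](O)[C@H]1O` gives < 5%, which is a limit of the assay and not a number.
Compound 2 `CC1OC(n2cnc3c(N)nccc32)CC1O` gives 25%.
Compound 3 `OC[C@H]1OC(n2cnc3c(SCc4ccccc4)nccc32)[C@H](O)[C@@H]1O` gives 30%.

The numbers of compound 2 and compound 3 lie within the scatter of each other, so neither stands apart; the third value is only a limit. For the measured compounds named here, the one measured step, a number at least 25 percentage points higher from compound 1 to compound 3 (beyond the scatter), came from adding phenyl in place of hydrogen on a saturated chain carbon bound to a sulfur, and it started from a limit (the limit of < 5% in this assay, at which 1 of the 3 values shown sits). Compound 4 `[N-]=[N+]=Nc1nccc2c1ncn2C1O[C@H](CO)[C@@H](O)[C@H]1O` reverses that gain and more: azido in place of benzylsulfanyl on an aromatic carbon. With the benzylsulfanyl gone, the step is expected to run the other way, about a number 22 percentage points lower from compound 3 to compound 4 (beyond the scatter), so compound 4 is estimated at 8%, between 2% and 20%.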

Compound 4, a percentage reported as inhibition, at one concentration (the size of the read-out at that concentration, not a potency): < 5%
Compound 4: only a limit was reported; the forecaster's own chance of this, stated with the estimate: 40%; middle value at least 3 percentage points from the limit.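

In this assay, azido in place of benzylsulfanyl on this aromatic carbon gives a number at least 25 percentage points lower from compound 3 to compound 4 (beyond the scatter), so both methylsulfanyl in compound 1 and azido in compound 4 lack the inhibition seen with the benzylsulfanyl group of compound 3. Compound 4 gives < 5%, which is a limit of the assay and not a number: the limit of < 5% in this assay, at which 2 of the 4 values shown sit.

The step between compound 1 and compound 4 cannot be read, so these two groups cannot be ranked against each other. From the compounds shown here alone, whether an amine on this aromatic carbon, or a longer chain between the sulfur and the phenyl ring, would keep the inhibition remains open.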